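This account rests on a few compounds, and the source may have more. Where it says the series, first, only, none or still open, it means among the compounds named here.

Three compounds have been measured in a functional assay on DU-145 cells (Homo sapiens) for cytotoxicity, read by MTT assay, with a stated time of 48 h; on this read-out higher numbers stand for weaker inhibition and lower numbers for stronger inhibition:

Compound 1 `Cc1ccc(S(=O)(=O)/N=C(/CCNC2=CC(=O)c3ccccc3C2=O)Nc2ccccc2[N+](=O)[O-])cc1` gives 7590 nM.
Compound 2 `Cc1ccc(S(=O)(=O)/N=C(/CCNC2=CC(=O)c3ccccc3C2=O)Nc2cccc(C(F)(F)F)c2)cc1` gives 84100 nM.
Compound 3 `COc1ccc(N/C(CCNC2=CC(=O)c3ccccc3C2=O)=N\S(=O)(=O)c2ccc(C)cc2)cc1OC` gives 17800 nM.

Compound 3 stands second highest of the three, between the others. Its nearest neighbour is compound 1: a 2.3-fold higher number from compound 1 to compound 3 (0.37 log units; beyond the scatter). Its furthest neighbour is compound 2: a 4.7-fold lower number from compound 2 to compound 3 (0.67 log units; beyond the scatter). Both steps replace one whole aromatic group on the amine nitrogen with another, and together they show that the identity of this group moves the numbers by modest amounts.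

Compound 4 `COc1cc(N/C(CCNC2=CC(=O)c3ccccc3C2=O)=N\S(=O)(=O)c2ccc(C)cc2)cc(OC)c1OC` differs from compound 3 in a smaller way: methoxy in place of hydrogen on an aromatic carbon. For the measured compounds named here, no measured step adds or removes a single methoxy group, so none bears directly on this change; the two steps that reach compound 3 only set the scale of what whole-group swaps do. With no closer guide, the expected step is small, within the scatter, in no firm direction: a 1.1-fold lower number from compound 3 to compound 4 (0.05 log units; within the scatter). Compound 4 is therefore estimated at 16000 nM, expected between 6000 nM and 45000 nM.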

Compound 4, half-maximal inhibitory concentration: 9330 nM
Beside the measured number, compound 4's estimate is 1.7-fold (0.23 log units) above it, within the range that was stated.
By their numbers in this assay, from the lowest: compounds 1, 4 and 3 (each within the scatter of the next, the first and the last beyond it); then compound 2.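

In this assay, for the compounds shown here, the first direct look at adding one methoxy group to this aromatic ring gives a 1.9-fold lower number from compound 3 to compound 4 (0.28 log units; within the scatter) and so stays within the usual scatter. The 3,4,5-trimethoxyphenyl group also stays within the scatter of the 2-nitrophenyl group, with a 1.2-fold higher number from compound 1 to compound 4 (0.09 log units; within the scatter) as the step, but it stands clearly apart from the 3-(trifluoromethyl)phenyl group, with a 9.0-fold lower number from compound 2 to compound 4 (0.95 log units; beyond the scatter) as the step, so compound 2 remains the one far from the other three. Nothing measured here explains these differences.

From the compounds shown here alone, it remains open whether a hydroxyl group or an amine on this same aromatic carbon would stay as close to compound 3 as methoxy does. It is also unknown whether adding a methoxy group would give so small a step on the 2-nitrophenyl or 3-(trifluoromethyl)phenyl rings.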